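Chain extension on the aminoalcohol series: a second test

The source may report more compounds than this note shows. Statements on the series, on what has been measured and on what is new or still open speak of the compounds shown alone.

Compound 3 `CCCCCCCCC[C@@H](O)[C@@H](N)C(C)C` gives 11000 nM in a functional assay on WiDr cells (Homo sapiens) for antiproliferative activity, read by sulforhodamine B assay, with a stated time of 48 h; a lower number here means a stronger inhibitor of growth, a higher number a weaker inhibitor of growth. Compound 1 `CCCCCCCCCCCCCCC[C@@H](O)[C@@H](N)C(C)C` carries the change hexyl in place of hydrogen on a saturated chain carbon, ten or more bonds along the chain from an oxygen on a saturated carbon and in this assay compound 1 gives 20000 nM, the step being a 1.8-fold higher number from compound 3 to compound 1 (0.26 log units; within the scatter). Compound 2 `CCCCCCCCC[C@@H](O)[C@H](C)N` differs from compound 3 in its core by methyl in place of isopropyl on a saturated chain carbon bound to an amine nitrogen and a saturated chain carbon; in this assay compound 2 gives 17000 nM, and the step is a 1.5-fold lower number from compound 2 to compound 3 (0.19 log units; within the scatter). Compound 4 `CCCCCCCCCCCCCCC[C@@H](O)[C@H](C)N`, not yet measured, carries the same change starting from compound 2, namely (hexyl in place of hydrogen on a saturated chain carbon, ten or more bonds along the chain from an oxygen on a saturated carbon), at a place described in the same words as for compound 1. Going by the values given here, the expected step in this assay is a 1.6-fold higher number from compound 2 to compound 4 (0.22 log units; within the scatter), set beside the earlier one, because a 1.8-fold higher number from compound 3 to compound 1 (0.26 log units; within the scatter) is the only read-out of this change and lies within the scatter. Compound 4 is accordingly estimated at 28000 nM, with a range from 12000 nM to 65000 nM.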

Compound 4, concentration for 50% growth inhibition: 700 nM
Beside the measured number, compound 4's estimate is 40-fold (1.60 log units) above it, and the stated range ends above it.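

In this assay the hexyl change does not carry from one core to the other, since it gives a 24-fold lower number from compound 2 to compound 4 (1.39 log units; beyond the scatter) and the two read-outs disagree: the same change on two cores in this assay, a 1.8-fold higher number (0.26 log units; within the scatter) from compound 3 to compound 1 and a 24-fold lower number (1.39 log units; beyond the scatter) from compound 2 to compound 4, 44-fold (1.64 log units) apart, beyond the scatter of two such steps. The change of isopropyl to methyl is likewise not transferable between the shorter and longer chains, with a 29-fold lower number from compound 1 to compound 4 (1.46 log units; beyond the scatter) as its new read-out: the same change on two cores in this assay, a 1.5-fold lower number (0.19 log units; within the scatter) from compound 2 to compound 3 and a 29-fold higher number (1.46 log units; beyond the scatter) from compound 4 to compound 1, 44-fold (1.64 log units) apart, beyond the scatter of two such steps. These four compounds show that the two changes do not act independently in this assay, but they do not show why, and one pair per change cannot support a general rule for the series.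

On these data alone, it remains open whether the low number of compound 4 persists with a longer chain, or with ethyl in place of methyl on the saturated chain carbon bound to an amine nitrogen. Chain lengths between those of compound 2 and compound 4 also remain open.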